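Amide nitrogen substitution and cytotoxicity across the series

The source may report more compounds than this note shows. Statements on the series, on what has been measured and on what is new or still open speak of the compounds shown alone.

Working notes on a small set sharing a core that carries a tertiary alcohol with two trifluoromethyl groups. Compound 1 `CN(C(=O)c1ccccc1)c1ccc(C(O)(C(F)(F)F)C(F)(F)F)cc1` bears a methyl on the amide-type nitrogen and a phenyl on the carbonyl carbon; in an ADME assay on Li23 cells (Homo sapiens) for cytotoxicity, read by WST assay (on this read-out higher numbers stand for lower toxicity in this test and lower numbers for higher toxicity in this test), compound 1 gives 65000 nM. Compound 2 `CN(C(=O)c1ccccn1)c1ccc(C(O)(C(F)(F)F)C(F)(F)F)cc1` has pyridin-2-yl in place of that phenyl. In this assay compound 2 reaches only a limit of the assay, > 100000 nM, namely (the limit of > 100000 nM in this assay, at which 1 of the 3 values shown sits). The step is an at least 1.5-fold higher number from compound 1 to compound 2 (0.18 log units; that floor lies within the scatter). Compound 3 `O=C(Nc1ccc(C(O)(C(F)(F)F)C(F)(F)F)cc1)c1ccccc1` lacks the methyl; in this assay compound 3 gives 12000 nM, the lowest of the two numbers, with compound 1 the nearest, and the step was a 5.4-fold lower number from compound 1 to compound 3 (0.73 log units; beyond the scatter).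

Compound 4 `CCN(C(=O)c1ccccc1)c1ccc(C(O)(C(F)(F)F)C(F)(F)F)cc1` differs from compound 3 by ethyl in place of hydrogen on an amide-type nitrogen. Within the data shown here, the only measured step that bears on this change is the one from compound 1 to compound 3, where a methyl on the same nitrogen went with the higher number of compound 1. Ethyl is not methyl, so the size is uncertain, but the direction is expected to be upward, toward compound 1. Compound 4 is therefore expected near 50000 nM, within 18000 nM to 130000 nM. That estimate means an expected step of a 4.2-fold higher number from compound 3 to compound 4 (0.62 log units; beyond the scatter).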

Compound 4, half-maximal cytotoxic concentration: 19000 nM
Beside the measured number, compound 4's estimate is 2.6-fold (0.42 log units) above it; the measured number falls inside the stated range.
By their numbers in this assay, from the lowest: compounds 3 and 4 (each within the scatter of the next); then compound 1. At a limit, above all of these: compound 2.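

In this assay, the ethyl on the amide-type nitrogen does not repeat what the methyl did: a 1.6-fold higher number from compound 3 to compound 4 (0.20 log units; within the scatter), so the ethyl and hydrogen compounds cannot be told apart in this test. Extending the methyl by one saturated chain carbon does separate the two alkyl compounds, with a 3.4-fold lower number from compound 1 to compound 4 (0.53 log units; beyond the scatter), so the higher number at this position does not go with alkyl substitution in general: among compounds 1, 3 and 4, only compound 1 stands apart, and compound 4 goes against any such rule. The compounds shown offer no measurement that explains why the methyl and ethyl compounds differ.

From the compounds shown here alone, whether compound 1 marks a narrow optimum remains open, since a propyl group, a longer chain or a cyclopropyl group on the same nitrogen could either stay with compound 4 or move elsewhere. Also open, going by these compounds, is whether the pyridin-2-yl group on the carbonyl carbon would change the number when the nitrogen carries ethyl or hydrogen rather than methyl, and whether a 2-methoxyethyl chain on that nitrogen would follow the ethyl result.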